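A few compounds are considered here, and "the series" means these few. Any claim that something is new, unique, unknown or untested is made for them only; others in the source may bear on it.

Measured so far:
Compound 1, `CCC(CC)(CC)/N=C(\NC#N)Nc1cc(Cl)cc(C#N)c1`. In a functional assay with Cavia porcellus as the target (on this read-out higher numbers stand for an effect only at larger amounts of compound and lower numbers for an effect already at smaller amounts), compound 1 gives > 1 uM, which is a limit of the assay and not a number.
Compound 2, `CCC(CC)(CC)/N=C(\NC#N)Nc1cc(Cl)cc(Cl)c1`. In this assay compound 2 gives > 1 uM, again a limit rather than a number.

On the numbers shown, compound 1 therefore stands only at a limit; the limit of > 1 uM in this assay, at which 2 of the 2 values shown sit, tells where both shown values sit. For the measured compounds named here, the one step between measured compounds, a step that the two limits leave unreadable from compound 1 to compound 2, is left unreadable by the two limits, so it gives no size to carry over.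

Compound 3, `CCC(C)(CC)/N=C(\NC#N)Nc1cc(Cl)cc(C#N)c1`, differs from compound 1 by hydrogen in place of methyl on a saturated chain carbon, two bonds along the chain from a double-bonded nitrogen. Going by the values given here, no measured step concerns this part of the molecule, and the only measured step has no readable size, so nothing here points to a change in either direction. The account thus rests on where compound 1 stands: the step from compound 1 to compound 3 is expected to be a step that the limit leaves unreadable from compound 1 to compound 3, with another limit the most likely outcome. For compound 3 the estimate in this assay is 3 uM, within a range of 0.7 uM to 20 uM.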

Compound 3, concentration for half-maximal effect: 0.016 uM
For compound 3 the middle estimate is 190-fold (2.27 log units) above the measured one; the measured number lies below the stated range.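

The earlier values were limits and not numbers, so no step between them could be read, and that limit still holds most of the values shown: the limit of > 1 uM in this assay, at which 2 of the 3 values shown sit.

The change of 1,1-diethylpropyl to 1-ethyl-1-methylpropyl, hydrogen in place of methyl on a saturated chain carbon, two bonds along the chain from a double-bonded nitrogen, now gives in this assay an at least 62-fold lower number from compound 1 to compound 3 (1.79 log units; beyond the scatter). For the compounds shown here, this shows that the chain at this position, which no earlier step touched, strongly affects the read-out, with a single methyl making the difference between a limit and an effect already at smaller amounts of compound; since the value of compound 1 is only a limit, the size of this step is a minimum.

As far as these compounds go, whether the same change would carry over to compound 2, with chloro in place of cyano on the aromatic carbon, remains open. Also open, from the compounds shown here alone, is how far this chain can be altered, for instance whether a shorter tert-butyl group or a cyclohexyl ring in place of the 1-ethyl-1-methylpropyl would move the read-out further in either direction.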